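This account rests on a few compounds, and the source may have more. Where it says the series, first, only, none or still open, it means among the compounds named here.

In a functional assay on the whole organism with Rattus norvegicus as the target (a higher number here means that more compound is needed for the effect, a lower number that less compound is needed), compound 1 (`CCCOc1ccccc1-c1ncc(-c2nn[nH]n2)c(O)n1`) gives 0.04 mg/kg and compound 2 (`CC(C)Oc1ccccc1-c1ncc(-c2nn[nH]n2)c(O)n1`) gives 0.04 mg/kg so compound 2 stands level with compound 1. Within the data shown here, the one measured step on this oxygen, isopropyl in place of propyl, shows no change at the digits printed from compound 1 to compound 2 (within the scatter) in this series. Compound 3 (`CC(C)COc1ccccc1-c1ncc(-c2nn[nH]n2)c(O)n1`) differs from compound 2 by isobutyl in place of isopropyl on an oxygen on an aromatic ring with isobutyl in place of isopropyl on an oxygen on an aromatic ring. Among the measured compounds shown here, no measured compound carries isobutyl, so a single step is the only guide. An expected step of a 1.3-fold higher number from compound 2 to compound 3 (0.10 log units; within the scatter) would stay within the scatter in this assay with no clear direction. For compound 3 the estimated dose is 0.05 mg/kg with an expected range of 0.02 mg/kg to 0.15 mg/kg here.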

Compound 3, dose for 50% inhibition: 0.1 mg/kg
The estimate for compound 3 lay 2.0-fold (0.30 log units) below the measured number, within the range that was stated.
By their numbers in this assay, from the lowest: compounds 1 and 2 (each within the scatter of the next); then compound 3.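

In this assay, among these compounds, the position responds for the first time: isobutyl in place of isopropyl gives a 2.5-fold higher number from compound 2 to compound 3 (0.40 log units; beyond the scatter) on the same oxygen. Set against the propyl of compound 1, the added methyl on the chain gives a 2.5-fold higher number from compound 1 to compound 3 (0.40 log units; beyond the scatter) as well, so this oxygen tolerates the swap of propyl and isopropyl but not the move to isobutyl without a modest loss. No measurement here bears on the cause of these steps.

Going by these compounds, whether a longer chain such as butyl or pentyl follows isobutyl remains open. So does the effect of a shorter methyl or ethyl, or of an amine or carboxylic acid at the chain end.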